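This account rests on a few compounds, and the source may have more. Where it says the series, first, only, none or still open, it means among the compounds named here.

In a functional assay on CHO-K1 cells for antagonist activity at prostaglandin E2 receptor EP1 subtype (Homo sapiens), read by FLIPR (a higher number here means a weaker inhibitor, a lower number a stronger inhibitor), compound 1 `O=C(O)c1ccn(Cc2cc(Br)ccc2OCc2ccccc2)n1` gives 55 nM. Compound 2 `O=C(O)c1cn(Cc2cc(Br)ccc2OCc2ccccc2)nn1` returns only a limit in this assay, < 2000 nM. The step that the limit leaves unreadable from compound 1 to compound 2 therefore cannot be sized, because of the limit of < 2000 nM in this assay, at which 1 of the 3 values shown sits. Compound 3 `Cc1cc(C(=O)O)nn1Cc1cc(Br)ccc1OCc1ccc(Cl)cc1` gives 8.71 nM in this assay, the lowest of the two numbers actually read, with compound 1 the nearest and higher by a margin beyond the scatter. Compound 4 `Cc1cc(C(=O)O)nn1Cc1cc(Br)ccc1OCc1cccc(Cl)c1` carries 3-chlorophenyl in place of 4-chlorophenyl on a saturated chain carbon bound to an oxygen on an aromatic ring. For the measured compounds named here, no measured step touches the chlorobenzyl group; the single step available is unreadable and concerns a different part of the molecule. The expectation for compound 4 is thus a step of a 1.4-fold higher number from compound 3 to compound 4 (0.14 log units; within the scatter) staying within the scatter of compound 3, an estimated 12 nM in this assay with a range of 4 nM to 40 nM.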

Compound 4, inhibition constant: 427 nM
Beside the measured number, compound 4's estimate is 36-fold (1.55 log units) below it; the measured number lies above the stated range.
By their numbers in this assay, from the lowest: compound 3; then compound 1; then compound 4.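

In this assay, 3-chlorophenyl in place of 4-chlorophenyl on a saturated chain carbon bound to an oxygen on an aromatic ring is a large change, read as a 49-fold higher number from compound 3 to compound 4 (1.69 log units; beyond the scatter) and beyond the scatter. For the compounds shown here, this is the first readable step at this position, and it shows that moving the chlorine alone, with the same atoms kept, is enough to give a large loss. No measurement shown bears on the reason for the size of this step.

From the compounds shown here alone, whether a 4-fluorobenzyl or 4-methoxybenzyl group at this position would keep the number of compound 3 remains open. So does whether the same chlorine move would have a similar effect on the core of compound 1.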